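The compounds below may be only part of what the source reports. "The series", "measured", "known", "first", "only" and "open" are said of these compounds alone.

Compound 1 `O=C(/C(=C/c1ccccc1)CCl)c1ccccc1`: 23000 nM
Compound 2 `CC(=O)OC/C(=C\c1ccccc1)C(=O)c1ccccc1`: 20000 nM

Within the data shown here, in a functional assay on HeLa cells (Homo sapiens) for inhibition, read by sulforhodamine B assay, with a stated time of 48 h (on this read-out lower numbers stand for stronger inhibition of growth and higher numbers for weaker inhibition of growth), compound 2 stands at 20000 nM; its only neighbour is compound 1, and the step of a 1.2-fold lower number from compound 1 to compound 2 (0.06 log units; within the scatter) lies within the scatter, so the two compounds cannot be ordered. Compound 3 `CC(=O)OC/C(=C\c1ccccc1Br)C(=O)c1ccccc1` differs from compound 2 by bromo in place of hydrogen on an aromatic carbon. Among the measured compounds shown here, no measured step touches the aromatic ring; the one measured step, a 1.2-fold lower number from compound 1 to compound 2 (0.06 log units; within the scatter), concerns the chain and was within the scatter, so nothing supports a shift in either direction. Compound 3 is therefore expected to move by a 1.3-fold lower number from compound 2 to compound 3 (0.12 log units; within the scatter), no more than the scatter. The estimate for compound 3 is 15000 nM, ranging from 5000 nM to 50000 nM.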

Compound 3, concentration for 50% growth inhibition: 20000 nM
Compound 3: middle estimate off by 1.3-fold (0.12 log units), on the low side, and the stated range covers the measured number.
By their numbers in this assay, from the lowest: compounds 2, 3 and 1 (each within the scatter of the next).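

Among these compounds, the step of no change at the digits printed from compound 2 to compound 3 (within the scatter) in this assay gives the first reading on the aromatic ring, as the earlier step concerned only the chain. Bromo on an aromatic carbon, ortho to a large group, thus leaves the number within the scatter, as the change from chloro to acetoxy on the chain did. No measurement offered here explains this result. As far as these compounds go, whether an amine, a methoxy group or a carboxylic acid at this ring position would shift the number remains open. So does whether bromo at another ring carbon would.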